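The source may hold more compounds than are shown below. What is called first, only, known or untested is meant among the compounds shown, and "the series" means these compounds.

Compound 3 `COc1ccc(-c2sc(N)c(C(=O)c3cccc(C(F)(F)F)c3)c2CC(C)(C)C)cc1` stands level with compound 2 `COc1ccc(-c2sc(N)c(C(=O)c3ccc(Cl)c(Cl)c3)c2CC(C)(C)C)cc1` in an assay on CHO cells for displacement of a labelled ligand from adenosine receptor A3 (Homo sapiens), read by scintillation counting, tested at 10 uM; on this read-out lower numbers stand for less inhibition and higher numbers for more inhibition at the one concentration tested (going by the name of the read-out): compound 3 gives 1%, compound 2 gives 1%, and compound 1 `COc1ccc(-c2sc(N)c(C(=O)c3cccc(Cl)c3)c2CC(C)(C)C)cc1` gives 2%. The steps of a number 1 percentage points lower from compound 1 to compound 2 (within the scatter), a number 1 percentage points lower from compound 1 to compound 3 (within the scatter) and no change at the digits printed from compound 2 to compound 3 (within the scatter) all lie within the scatter, so the three measured compounds sit together at the low end of the read-out.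

Compound 4 `COc1ccc(-c2sc(N)c(C(=O)c3ccc(C)cc3)c2CC(C)(C)C)cc1` differs from compound 3 by 4-methylphenyl in place of 3-(trifluoromethyl)phenyl on a carbonyl carbon. The earlier exchange of the whole group on the carbonyl carbon, no change at the digits printed from compound 2 to compound 3 (within the scatter), and the two single-substituent changes, a number 1 percentage points lower from compound 1 to compound 2 (within the scatter) and a number 1 percentage points lower from compound 1 to compound 3 (within the scatter), produced nothing beyond the scatter in this assay. For compound 4 no step beyond the scatter is therefore expected, and the expected step is a number 1 percentage points higher from compound 3 to compound 4 (within the scatter). Compound 4 is estimated at 2%, with a range from -6% to 10%.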

Compound 4, a percentage reported as inhibition, at one concentration (the size of the read-out at that concentration, not a potency): 5%
Compound 4: the middle estimate sits 3 percentage points below what was measured, within the range that was stated.
By their numbers in this assay, from the lowest: compounds 2, 3, 1 and 4 (each within the scatter of the next).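

In this assay, within the data shown here, 4-methylphenyl on the carbonyl carbon, the first group here with carbon as its only heavy atoms, gives a number 4 percentage points higher from compound 3 to compound 4 (within the scatter), a number 4 percentage points higher from compound 2 to compound 4 (within the scatter) and a number 3 percentage points higher from compound 1 to compound 4 (within the scatter). Removing chlorine and fluorine from this group therefore shifts the read-out by no more than the scatter, so the four compounds do not separate at this position. No available evidence bears on these results.

Going by these compounds, whether an amine or a carboxylic acid on the aromatic ring of this group would move the read-out beyond the scatter stays open. The same holds for a longer chain in place of the ring.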